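The compounds below may be only part of what the source reports. "The series", "measured", "known", "first", "only" and "open" are said of these compounds alone.

In an assay on LtK cells with ATP-sensitive inward rectifier potassium channel 11 (Homo sapiens) as the target (on this read-out higher numbers stand for an effect only at larger amounts of compound and lower numbers for an effect already at smaller amounts), the measured compounds are:

- compound 1 `CC(C)C(=O)Nc1c(C(O)(C(F)(F)F)C(F)(F)F)ccc2ccccc12` gives 6630 nM
- compound 2 `CCC(CC)C(=O)Nc1c(C(O)(C(F)(F)F)C(F)(F)F)ccc2ccccc12` gives 4340 nM
- compound 3 `Cc1ccccc1C(=O)Nc1c(C(O)(C(F)(F)F)C(F)(F)F)ccc2ccccc12` gives 5550 nM

Compound 3 holds the second highest of these three numbers; its nearest and furthest neighbours are shown by a 1.2-fold lower number from compound 1 to compound 3 (0.08 log units; within the scatter) and a 1.3-fold higher number from compound 2 to compound 3 (0.11 log units; within the scatter), both within the scatter. Compound 4 `O=C(Nc1c(C(O)(C(F)(F)F)C(F)(F)F)ccc2ccccc12)c1cccc([N+](=O)[O-])c1` differs from compound 3 by 3-nitrophenyl in place of 2-methylphenyl on a carbonyl carbon. Among the measured compounds shown here, no measured step involves a nitrophenyl group; the steps that change the group on the carbonyl carbon, a 1.5-fold lower number from compound 1 to compound 2 (0.18 log units; within the scatter) and a 1.3-fold higher number from compound 2 to compound 3 (0.11 log units; within the scatter), all stayed within the scatter, so for compound 4 no step beyond the scatter is expected in this assay. Compound 4 is therefore estimated at 5000 nM, with a range from 1800 nM to 14000 nM. For compound 4 this expectation amounts to a 1.1-fold lower number from compound 3 to compound 4 (0.05 log units; within the scatter).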

Compound 4, half-maximal effective concentration: 117 nM
The estimate for compound 4 lay 43-fold (1.63 log units) above the measured number; the whole stated range lies above it.
By their numbers in this assay, from the lowest: compound 4; then compounds 2, 3 and 1 (each within the scatter of the next).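

Among the compounds shown here, on the carbonyl carbon, isopropyl, pentan-3-yl and 2-methylphenyl had stayed within the scatter of one another, but 3-nitrophenyl brings the first large steps in this assay: a 47-fold lower number from compound 3 to compound 4 (1.68 log units; beyond the scatter), a 37-fold lower number from compound 2 to compound 4 (1.57 log units; beyond the scatter) and a 57-fold lower number from compound 1 to compound 4 (1.75 log units; beyond the scatter). The read-out at this position therefore does respond to the group placed there, even though 2-methylphenyl and 3-nitrophenyl both carry one six-membered aromatic ring of carbon only. Nothing available accounts for these steps.

On these data alone, whether a phenyl carrying a nitrile or a carboxylic acid in place of the nitro group would give a comparable step remains open. Also open, as far as these compounds go, is whether the step belongs to the nitro group itself or to where it sits on the ring.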